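Shortening the Chain of Compound 2: Expected Cytotoxicity

This account rests on a few compounds, and the source may have more. Where it says the series, first, only, none or still open, it means among the compounds named here.

Three compounds have been run in an ADME assay on MDCK cells (Canis lupus familiaris) for cytotoxicity, read by microscopy, with a stated time of 6 days; on this read-out higher numbers stand for lower toxicity in this test and lower numbers for higher toxicity in this test. Compound 1, `CCCCCNc1nccnc1C(=O)NCc1ccccc1`, reached only a limit of the assay, >= 20000 nM. Compound 3, `CCCCCNc1cnc(C(=O)NCc2ccccc2)cn1`, likewise gave only a limit, > 100000 nM. Within the data shown here, compound 2, `CCCCCCCCNc1cncc(C(=O)NCc2ccccc2)n1`, is the single compound with an actual number, giving 4000 nM in this assay. It therefore stands alone among the values shown, the other two sitting at limits (the limit of > 100000 nM in this assay, at which 1 of the 3 values shown sits, (the limit of >= 20000 nM in this assay, at which 1 of the 3 values shown sits)). The unmeasured compound 4, `CCCCCCCNc1cncc(C(=O)NCc2ccccc2)n1`, differs from compound 2 in one place: hydrogen in place of methyl on a saturated chain carbon, seven bonds along the chain from a nitrogen on an aromatic ring. Among the measured compounds shown here, no step between measured compounds exists to gauge this change, so any expectation is loose. Compound 4 is expected to be slightly less toxic than compound 2, a step of a 2.0-fold higher number from compound 2 to compound 4 (0.30 log units; within the scatter), landing near 8000 nM with a range from 3000 nM to 30000 nM.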

Compound 4, minimum cytotoxic concentration: 4000 nM
Compound 4: the middle estimate sits 2.0-fold (0.30 log units) above what was measured; low and high end bracket the measured number.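

Replacing methyl with hydrogen on a saturated chain carbon, seven bonds along the chain from a nitrogen on an aromatic ring, gives in this assay no change at the digits printed from compound 2 to compound 4 (within the scatter). Among these compounds, this is the first measured step at this place, and it shows that this single change leaves the read-out where it was. Nothing shown explains this result.

A single step cannot show how much shorter chains on the shared core would behave. On these data alone, whether a longer chain, or an amine or a carboxylic acid on this chain carbon, would shift the number also stays open.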